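Lengthening a sulfur-bound chain: what to expect in mice

A few compounds are considered here, and "the series" means these few. Any claim that something is new, unique, unknown or untested is made for them only; others in the source may bear on it.

Compound 1 `CSc1nnc(Cc2ccccc2Oc2ccccc2)[nH]1` gives 133% in a functional assay on the whole organism (strain NMRI) with Mus musculus as the target, with a stated time of 60 min, at a dose of 10 mg/kg by the intraperitoneal route; on this read-out lower numbers stand for a weaker effect and higher numbers for a stronger effect at the one dose given. Compound 2 `CCSc1nnc(Cc2ccccc2Oc2ccccc2)[nH]1` carries methyl in place of hydrogen on a saturated chain carbon bound to a sulfur and in this assay compound 2 gives 142%; that change gave a number 9 percentage points higher from compound 1 to compound 2 (within the scatter). Compound 3 `CCSc1nnc(Cc2ccc(Cl)cc2Oc2ccccc2Cl)[nH]1` has a different core; the difference between the two cores is not broken down here. In this assay compound 3 gives 140%, within the scatter of compound 2 and of compound 1. Compound 4 `CCCSc1nnc(Cc2ccc(Cl)cc2Oc2ccccc2Cl)[nH]1` is not yet measured and differs from compound 3 by methyl in place of hydrogen on a saturated chain carbon, two bonds along the chain from a sulfur. This is the same kind of change as that from compound 1 to compound 2, though not the same, since there the place was on a saturated chain carbon bound to a sulfur, while here it is on a saturated chain carbon two bonds along the chain from a sulfur. Because the earlier step was a number 9 percentage points higher from compound 1 to compound 2 (within the scatter), a similar small step is expected now, a number 5 percentage points higher from compound 3 to compound 4 (within the scatter). Compound 4 is therefore expected to give 145% in this assay, roughly between 125% and 165%.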

Compound 4, a percentage reported as activity, at one dose (the size of the read-out at that dose, not a potency): 125%
For compound 4 the middle estimate is 20 percentage points above the measured one; measured number inside the range.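

In this assay, going from ethylsulfanyl to propylsulfanyl gave a number 15 percentage points lower from compound 3 to compound 4 (beyond the scatter). Set beside the earlier step, this kind of change does not carry over unchanged between the two cores: the same change on two cores in this assay, a number 9 percentage points higher (within the scatter) from compound 1 to compound 2 and a number 15 percentage points lower (beyond the scatter) from compound 3 to compound 4, 24 percentage points apart, beyond the scatter of two such steps

This rests on a single pair per core, with the added methyl at a different place on the chain in each pair; it gives no general rule for the series and does not say why the two steps part.

The compounds shown leave open how a longer chain such as butylsulfanyl would behave on either core. They also leave open whether propylsulfanyl on the core of compound 1 would follow the step seen with compound 4.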